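This account rests on a few compounds, and the source may have more. Where it says the series, first, only, none or still open, it means among the compounds named here.

Measured so far:
compound 1, `C=Cc1cccc(C(=O)N2CCCC(C(=O)Nc3ccc(Cl)cc3)C2)c1`, 0% in an ADME assay on PC-3 cells (Homo sapiens) for cytotoxicity, read by WST assay, tested at 100 uM; a higher number here means more inhibition at the concentration tested (going by the name of the read-out), a lower number less inhibition;
compound 2, `Cc1cccc(C(=O)N2CCCC(C(=O)Nc3ccc(Cl)cc3)C2)c1`, 0%;
compound 3, `Cc1nc(-c2cccc(NC(=O)C3CCCN(C(=O)c4cc(C(F)(F)F)cc(C(F)(F)F)c4)C3)c2)cs1`, 1%.

In this assay compound 3 gives a number that sits within the scatter of both compound 1 and compound 2; none of the three shows inhibition beyond the scatter. Among the measured compounds shown here, the only step between measured compounds, no change at the digits printed from compound 1 to compound 2 (within the scatter), is a change on another aromatic ring and gave nothing. Compound 4, `O=C(Nc1cccc([N+](=O)[O-])c1)C1CCCN(C(=O)c2cc(C(F)(F)F)cc(C(F)(F)F)c2)C1`, carries the change (nitro in place of 2-methyl-1,3-thiazol-4-yl on an aromatic carbon). For the measured compounds named here, no measured step covers this exchange, so the expectation rests only on the flat numbers of the three compounds: a step of a number 1 percentage points higher from compound 3 to compound 4 (within the scatter) is expected, that is none beyond the scatter. Compound 4 is therefore estimated at 2%, between 0% and 12%.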

Compound 4, a percentage reported as inhibition, at one concentration (the size of the read-out at that concentration, not a potency): 9%
For compound 4 the middle estimate is 7 percentage points below the measured one; the measured number falls inside the stated range.
By their numbers in this assay, from the lowest: compounds 1, 2, 3 and 4 (each within the scatter of the next).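

Among the compounds shown here, the first measured change at this aromatic carbon, meta to a large group, replaces a ring-bearing group of 6 heavy atoms with a ringless one of 3. In this assay it gives a number 8 percentage points higher from compound 3 to compound 4 (within the scatter), so this exchange moves the number no further than the scatter. Nothing measured here bears on why the number comes out this way.

Still open, from the compounds shown here alone, is whether an amine or a carboxylic acid on this carbon would give a number beyond the scatter. Going by these compounds, whether nitro would behave alike on the core of compound 1 also stays open.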